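This account rests on a few compounds, and the source may have more. Where it says the series, first, only, none or still open, it means among the compounds named here.

Compound 1 is `CCCSc1nc(Cl)c2c(n1)N(Cc1ccccc1)C(C(=O)N1CCN(C(=O)OC(C)(C)C)CC1)N2` and in a functional assay on PC-3 cells (Homo sapiens) for antiproliferative activity, read by MTT assay, with a stated time of 72 h (a lower number here means a stronger inhibitor, a higher number a weaker inhibitor), compound 1 gives 47100 nM. Compound 2 is `CCCSc1nc(Cl)c2c(n1)N(Cc1ccccc1)C(C(=O)NCCC1=CCc3ccccc31)N2`; for compound 2 the assay reports only a limit, > 64000 nM, which is the limit of > 64000 nM in this assay, at which 1 of the 3 values shown sits. Compound 3 is `CCCSc1nc(Cl)c2c(n1)N(Cc1ccccc1)C(C(=O)NCCNC(=O)OC(C)(C)C)N2` and in this assay compound 3 gives 29700 nM.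

Of the two numbers shown, compound 3 has the lowest, but compound 1 sits within the scatter of it, so the two cannot be told apart. Within the data shown here, the only measured step, an at least 2.1-fold lower number from compound 2 to compound 3 (0.33 log units; beyond the scatter), exchanged the aryl-bearing chain of compound 2 for the carbamate-bearing chain of compound 3 and gave an at least modest move toward stronger inhibition.

Compound 4 is `CCCSc1nc(Cl)c2c(n1)N(Cc1ccccc1)C(C(=O)NCC(C)C)N2`. Relative to compound 3 the change is isopropyl in place of ((tert-butoxycarbonyl)amino)methyl on a saturated chain carbon bound to an amide-type nitrogen, so the carbamate that entered in the single measured step is now taken away again and replaced by a small hydrocarbon group. Among the measured compounds shown here, no measured step touches this exact exchange; the one step available shows that a chain carrying the carbamate did better than a chain carrying an aromatic ring, which hints that losing the carbamate may push the number up, though by an uncertain amount. A step of a 1.6-fold higher number from compound 3 to compound 4 (0.21 log units; within the scatter) is therefore expected, toward a higher number. Compound 4 is estimated to give 48000 nM in this assay, within the range 20000 nM to 110000 nM.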

Compound 4, half-maximal inhibitory concentration: > 64000 nM
Compound 4 was reported as a limit; the forecaster's own chance of this, stated with the estimate: 35%; middle value at least 1.3-fold (0.12 log units) from the limit.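

Replacing ((tert-butoxycarbonyl)amino)methyl with isopropyl on a saturated chain carbon bound to an amide-type nitrogen gives an at least 2.1-fold higher number from compound 3 to compound 4 (0.33 log units; beyond the scatter) in this assay, so a small hydrocarbon group at this place does not keep the measurable effect of compound 3. Among the four compounds shown, a pattern now appears with no exception: compound 1 and compound 3 carry a tert-butoxycarbonyl group and give measured numbers, while compound 2 and compound 4 lack it, one with a ring-bearing chain and one with a small branched chain, and are reported only as limits. Compound 2 and compound 4 therefore cannot be ranked against each other, so the step between them cannot be read: the limit of > 64000 nM in this assay, at which 2 of the 4 values shown sit.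

As far as these compounds go, what remains open is which part of the carbamate-bearing chain goes with the measured number, the tert-butyl end, the carbonyl or the nitrogen with its hydrogen. A free amine on the same chain, an acetamide in its place, or a longer chain ending in the same tert-butoxycarbonyl amino group would help to separate these parts.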